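The source may hold more compounds than are shown below. What is called first, only, known or untested is meant among the compounds shown, and "the series" means these compounds.

Of the compounds shown here, three have been measured in an assay (Equus caballus) for inhibition of Thromboxane-A synthase (Homo sapiens), using microsomes; on this read-out higher numbers stand for weaker inhibition and lower numbers for stronger inhibition. Compound 1 `O=C(O)C(CCC/C=C(\c1ccccc1)c1cccnc1)Sc1ccccc1` gives 33 nM. Compound 2 `O=C(O)CCCC/C=C(\c1cccnc1)c1cccc(F)c1` gives 55 nM. Compound 3 `COc1ccc(/C(=C/CCCCC(=O)O)c2cccnc2)cc1` gives 80 nM, the highest of the three numbers; its gap to compound 2 is within the usual scatter, so no order can be claimed between those two, while its gap to compound 1 lies beyond the scatter, so compound 1 inhibits more strongly than compound 3.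

Compound 4 `Cc1ccc(/C(=C/CCCCC(=O)O)c2cccnc2)cc1` has not yet been measured. It differs from compound 3 in a single place: methyl in place of methoxy on an aromatic carbon. Among the measured compounds no pair differs in only one place, so no measured step shows how this kind of change moves the read-out. The expectation for compound 4 therefore rests on compound 3 alone and on the small size of the change. Compound 4 is expected to inhibit at about 70 nM, with a plausible range from 25 nM to 200 nM. The expected step, a 1.1-fold lower number from compound 3 to compound 4 (0.06 log units; within the scatter), would lie within the usual scatter, with no direction claimed beyond it. What this assay actually returns for compound 4 remains to be seen.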

Compound 4, half-maximal inhibitory concentration: 85 nM
Compound 4: the middle estimate sits 1.2-fold (0.08 log units) below what was measured; low and high end bracket the measured number.
By their numbers in this assay, from the lowest: compounds 1, 2, 3 and 4 (each within the scatter of the next, the first and the last beyond it).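

In this assay, among these compounds, the swap of methoxy for methyl gives the first direct reading at this aromatic carbon, para to a large group: a 1.1-fold higher number from compound 3 to compound 4 (0.03 log units; within the scatter). The change takes away one heavy atom and the one hydrogen-bond acceptor counted on methoxy, yet no order can be claimed between the two compounds, so at this position the read-out does not separate these two groups. A second single-place change, 4-methylphenyl in place of 3-fluorophenyl on the double-bonded chain carbon, gives a 1.5-fold higher number from compound 2 to compound 4 (0.19 log units; within the scatter), so the three compounds with the unbranched acid chain cannot be ordered by these two changes, and nothing measured here offers an explanation for that.

What the compounds shown leave open is whether a hydroxyl, an amine or a larger group such as a phenyl at the same aromatic carbon would also leave the number within the scatter. As far as these compounds go, it also remains open whether the swap from methoxy to methyl would behave the same way on the core of compound 1, which carries a different chain.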